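The source may report more compounds than this note shows. Statements on the series, on what has been measured and on what is new or still open speak of the compounds shown alone.

Compound 3 `Cc1ccc(NC(=O)NC(=O)c2ccc(OCc3cccc(Cl)c3)cc2)cc1-c1nc2ccccc2[nH]1` gives 28000 nM in a functional assay on MNK45 cells (Homo sapiens) for inhibition, read by MTT assay, with a stated time of 48 h (a lower number here means a stronger inhibitor, a higher number a weaker inhibitor), the highest of the three numbers measured. Compound 1 `O=C(NC(=S)Nc1ccc(Cl)c(-c2nc3ccccc3[nH]2)c1)c1ccc(OCc2ccc(Cl)c(Cl)c2)cc1` gives 4600 nM and compound 2 `O=C(NC(=S)Nc1ccc(Cl)c(-c2nc3ccccc3[nH]2)c1)c1ccc(OCc2ccc(Cl)cc2Cl)cc1` gives 3750 nM in this assay; both carry a different core from compound 3 together with a dichlorophenyl group, so their lower numbers cannot be tied to any single change. Compound 4 `Cc1ccc(NC(=O)NC(=O)c2ccc(OCc3ccc(Cl)c(Cl)c3)cc2)cc1-c1nc2ccccc2[nH]1` differs from compound 3 by chloro in place of hydrogen on an aromatic carbon, which read one bond further out is 3-chlorobenzyl to 3,4-dichlorobenzyl. Going by the values given here, the only measured step, a 1.2-fold lower number from compound 1 to compound 2 (0.09 log units; within the scatter), exchanges one dichloro pattern for another and does not test adding a second chloro. Compound 4 is therefore expected to move by a 1.9-fold lower number from compound 3 to compound 4 (0.27 log units; within the scatter), a modest and uncertain lowering, with an estimated value of 15000 nM and a range from 5000 nM to 40000 nM.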

Compound 4, half-maximal inhibitory concentration: 5820 nM
For compound 4 the middle estimate is 2.6-fold (0.41 log units) above the measured one; low and high end bracket the measured number.
By their numbers in this assay, from the lowest: compounds 2, 1 and 4 (each within the scatter of the next); then compound 3.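

In this assay, adding a second chloro to the 3-chlorobenzyl group gives a real gain: a 4.8-fold lower number from compound 3 to compound 4 (0.68 log units; beyond the scatter). Going by these compounds alone, this is the first direct test of that addition, with the new chloro ortho to a chloro group and para to a large group, whereas the earlier step only exchanged one dichloro pattern for another. Nothing measured here explains the gain.

Still open, going by these compounds, is whether chloro itself is needed at this carbon, or whether a fluoro, methyl or methoxy group would serve as well. On these data alone, it is also open whether the same addition would lower the number on the core of compound 1.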